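Stripping the ester from a cyclohexanol anilide

The source may report more compounds than this note shows. Statements on the series, on what has been measured and on what is new or still open speak of the compounds shown alone.

Among the compounds with values here, compound 2 `CCC(=O)OC1(C(=O)Nc2ccc([N+](=O)[O-])cc2)CCCCC1` gives the lowest of the two numbers measured so far: in an ADME assay on WI-38 cells (Homo sapiens) for inhibition, read by MTT assay, with a stated time of 72 h (on this read-out lower numbers stand for stronger inhibition and higher numbers for weaker inhibition), compound 2 gives 44.6 nM. Within the data shown here, the only neighbour on this scale is compound 1 `Cc1ccccc1C(=O)OC1(C(=O)Nc2ccc([N+](=O)[O-])cc2)CCCCC1`, which in this assay gives 352 nM; the single step of a 7.9-fold lower number from compound 1 to compound 2 (0.90 log units; beyond the scatter) replaced the 2-methylphenyl on the carbonyl carbon with an ethyl. Compound 3 `O=C(Nc1ccc([N+](=O)[O-])cc1)C1(O)CCCCC1` goes one cut further along the same side chain: hydrogen in place of propanoyl on an oxygen on a saturated carbon, so that the ester is gone and a free hydroxyl remains on the saturated ring carbon. Among the measured compounds shown here, the one measured step bears on this only loosely, since it compared two esters while here the ester itself disappears, so a large change is not expected in either direction. Compound 3 is estimated at 30 nM, within a range of 8 nM to 150 nM, which means an expected step of a 1.5-fold lower number from compound 2 to compound 3 (0.17 log units; within the scatter).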

Compound 3, half-maximal inhibitory concentration: 1220 nM
Beside the measured number, compound 3's estimate is 41-fold (1.61 log units) below it; measured number outside the range, above it.
By their numbers in this assay, from the lowest: compound 2; then compound 1; then compound 3.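

In this assay, taking the propanoyl off the oxygen to leave a free hydroxy is a far larger change than exchanging one ester for another (a 27-fold higher number from compound 2 to compound 3 (1.44 log units; beyond the scatter)). The same holds against the other ester (a 3.5-fold higher number from compound 1 to compound 3 (0.54 log units; beyond the scatter)), so both esters shown give lower numbers than the free hydroxy, and no compound here goes against that. This shows that the acyl group on this oxygen counts for much of the low number in compound 2, though nothing available explains the loss.

The compounds shown leave open whether a methyl ether or an amine at this place would keep the low number or behave like the free hydroxy. They also leave open whether a longer chain on the carbonyl carbon would lower the number further or raise it toward that of compound 1.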